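The source may hold more compounds than are shown below. What is called first, only, known or untested is meant among the compounds shown, and "the series" means these compounds.

Compound 1 `C=CCn1c(=O)n(C(=O)NCCN2CCN(C)CC2)c2ccccc21`: 0.63 in a functional assay for agonist activity at 5-hydroxytryptamine receptor 4 (Cavia porcellus); on this read-out higher numbers stand for larger maximal responses and lower numbers for smaller maximal responses.
Compound 2 `CCn1c(=O)n(C(=O)NCCN2CCN(C)CC2)c2ccccc21`: < 0.3 in this assay, which is a limit of the assay and not a number.

Compound 2 thus stands at the limit, (the limit of < 0.3 in this assay, at which 1 of the 2 values shown sits), so only an upper bound is known for it. Compound 3 `CCCn1c(=O)n(C(=O)NCCN2CCN(C)CC2)c2ccccc21` differs from compound 2 by methyl in place of hydrogen on a saturated chain carbon, two bonds along the chain from an aromatic nitrogen. Within the data shown here, the only measured step, a number at least 0.33 lower from compound 1 to compound 2 (beyond the scatter), changes the same chain but by another group, vinyl against methyl, so it bears on this step only in part. Some recovery is expected, and the expected step from compound 2 is a number at least 0.10 higher from compound 2 to compound 3 (that floor lies within the scatter). Compound 3 is estimated at 0.4, between 0.2 and 0.6.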

Compound 3, intrinsic activity: the largest response reached, as a fraction of the reference agonist's: 0.48
Compound 3: the middle estimate sits 0.080 below what was measured, and the stated range covers the measured number.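

At this position, two bonds along the chain from an aromatic nitrogen, a methyl in place of hydrogen raises the maximal response in this assay, with a number at least 0.18 higher from compound 2 to compound 3 (beyond the scatter) as the printed step. Compound 2 remains a limit of the assay and not a number: the limit of < 0.3 in this assay, at which 1 of the 3 values shown sits. Chain length alone does not match the vinyl-bearing chain, since a number 0.15 lower from compound 1 to compound 3 (beyond the scatter) follows ethyl in place of vinyl.

As far as these compounds go, whether a longer chain such as butyl raises the response further remains open. So does the effect of an amine or a hydroxyl at the end of this chain.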